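Replacing Methyl with a Hydroxyphenyl Arm on the Core

The compounds below may be only part of what the source reports. "The series", "measured", "known", "first", "only" and "open" are said of these compounds alone.

Within the data shown here, compound 1 `Cc1nc(N)c2nc(-c3ccccc3)sc2n1` stands at the weak end of the two compounds measured so far: in an assay on CHO cells for displacement of a labelled ligand from adenosine receptor A3 (Homo sapiens), read by scintillation counting, with a stated time of 3 h (a lower number here means a stronger inhibitor, a higher number a weaker inhibitor), compound 1 gives 2660 nM, the highest of the two numbers. Compound 2 `Nc1nc(-c2ccc(CO)cc2)nc2sc(-c3ccccc3)nc12` carries 4-(hydroxymethyl)phenyl in place of methyl on an aromatic carbon, and in this assay compound 2 gives 8.2 nM; the step of a 320-fold lower number from compound 1 to compound 2 (2.51 log units; beyond the scatter) is large. Compound 3 `Nc1nc(-c2cccc(O)c2)nc2sc(-c3ccccc3)nc12` makes a related change to compound 1: 3-hydroxyphenyl in place of methyl on an aromatic carbon. Among the measured compounds shown here, the only measured step that bears on this is the one from compound 1 to compound 2, where a six-membered aromatic ring with one oxygen replaced the same methyl and the number fell steeply. A step of similar direction, and probably similar size, is therefore expected in this assay, with some uncertainty because the entering ring here is 3-hydroxyphenyl rather than 4-(hydroxymethyl)phenyl. Compound 3 is expected to give 15 nM, within a range from 3 nM to 90 nM, meaning the expected step of a 180-fold lower number from compound 1 to compound 3 (2.25 log units; beyond the scatter).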

Compound 3, inhibition constant: 190 nM
Compound 3: the middle estimate sits 13-fold (1.10 log units) below what was measured, outside the stated range (above it).
By their numbers in this assay, from the lowest: compound 2; then compound 3; then compound 1.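

In this assay, the gain over methyl at this position is not confined to one arm: 3-hydroxyphenyl also gives a 14-fold lower number from compound 1 to compound 3 (1.15 log units; beyond the scatter) and so lands clearly on the stronger side of compound 1. The choice of arm matters too, with a 23-fold higher number from compound 2 to compound 3 (1.36 log units; beyond the scatter) showing that a six-membered aromatic ring at this position does not by itself reach the number of compound 2. Nothing available explains the gap between these two arms.

In both changes the ring and its oxygen-bearing group enter together, so their contributions cannot be separated. Going by these compounds, it remains open how plain phenyl would compare here, and whether an amine, a carboxylic acid or a longer chain on the arm would bring the number closer to that of compound 2.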